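A few compounds are considered here, and "the series" means these few. Any claim that something is new, unique, unknown or untested is made for them only; others in the source may bear on it.

Three compounds in this series share one core and differ only in the group attached to one aromatic carbon. Compound 1 `CN(C)CC(=O)Nc1cccc(Nc2ncc(F)c(Nc3ccc(F)cc3)n2)c1` carries a short amide-type group there and in a functional assay on A549 cells (Homo sapiens) for antiproliferative activity, read by sulforhodamine B assay, with a stated time of 3 days (a higher number here means a weaker inhibitor of growth, a lower number a stronger inhibitor of growth), gives 1180 nM. Compound 2 `COc1ccc(NC(=O)c2cccc(Nc3ncc(F)c(Nc4ccc(F)cc4)n3)c2)cc1` carries an aryl amide instead, and in this assay compound 2 gives 11000 nM. Compound 3 `O=C(Nc1ccccn1)c1cccc(Nc2ncc(F)c(Nc3ccc(F)cc3)n2)c1` has a pyridin-2-yl in place of the 4-methoxyphenyl on the amide-type nitrogen and gives 15300 nM. Among the three numbers compound 2 sits second highest: its value and that of compound 3 lie within the usual scatter of each other, while compound 1 is well apart, as the step of a 9.3-fold higher number from compound 1 to compound 2 (0.97 log units; beyond the scatter) shows.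

Compound 4 `COCC(=O)Nc1cccc(Nc2ncc(F)c(Nc3ccc(F)cc3)n2)c1` is the next candidate, and the change from compound 2 is ((methoxymethyl)carbonyl)amino in place of (4-methoxyphenyl)carbamoyl on an aromatic carbon. Among the measured compounds shown here, the only measured step that bears on such a change is the one between compound 1 and compound 2, since compound 1 also carries a small amide-type group on that carbon; read the other way round, a 9.3-fold higher number from compound 1 to compound 2 (0.97 log units; beyond the scatter) means that trading the aryl amide for the short chain gave a markedly lower number. A lower number is therefore expected for compound 4, though the swap of a dimethylamino for a methoxy within the chain leaves the size uncertain, so the expected step is a 4.4-fold lower number from compound 2 to compound 4 (0.64 log units; beyond the scatter). Compound 4 is estimated at 2500 nM, with a range from 800 nM to 8000 nM.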

Compound 4, concentration for 50% growth inhibition: 2050 nM
For compound 4 the middle estimate is 1.2-fold (0.09 log units) above the measured one, and the stated range covers the measured number.
By their numbers in this assay, from the lowest: compounds 1 and 4 (each within the scatter of the next); then compounds 2 and 3 (each within the scatter of the next).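

Until now the short chain on this aromatic carbon had appeared only with a dimethylamino group at its end, so the gap to the aryl amides could have depended on that amine. Compound 4 shows that it need not: in this assay the step of a 1.7-fold higher number from compound 1 to compound 4 (0.24 log units; within the scatter) puts methoxy in place of dimethylamino, and the two values cannot be told apart. The gap to the aryl amides remains with this ringless chain, as a 5.4-fold lower number from compound 2 to compound 4 (0.73 log units; beyond the scatter) and a 7.5-fold lower number from compound 3 to compound 4 (0.87 log units; beyond the scatter) show, although no measurement here speaks to the cause of these steps.

Each of these two steps changes the size of the group, removes its ring and reverses the amide link all at once, so the compounds shown leave open which of these differences matters. A short alkyl chain on the nitrogen of a carbamoyl group would separate the link from the ring, while a longer chain or a carboxylic acid at the end of the short chain would test how much the chain itself can vary.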